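A few compounds are considered here, and "the series" means these few. Any claim that something is new, unique, unknown or untested is made for them only; others in the source may bear on it.

Compound 1 `O=C1CC(c2nc(-c3cccc(Cl)c3)no2)CN1c1ccc(Cl)cc1` carries the shared core of this small set and, in an in vitro functional assay on HEK293-A cells for positive allosteric modulation of metabotropic glutamate receptor 5 (Homo sapiens), read by FLIPR and calcium flux (a lower number here means that less compound is needed, a higher number that more compound is needed for the effect), gives 140 nM, the lowest of the three measured numbers. Compound 3 `O=C1CC(c2nc(-c3cccc(F)c3)no2)CN1c1ccc(Cl)cc1` gives 630 nM in this assay, and compound 2 `COc1cccc(-c2noc(C3CC(=O)N(c4ccc(Cl)cc4)C3)n2)c1` gives 4800 nM. Every measured step alters the substituent on the other aromatic ring: a 4.5-fold higher number from compound 1 to compound 3 (0.65 log units; beyond the scatter), a 34-fold higher number from compound 1 to compound 2 (1.54 log units; beyond the scatter) and a 7.6-fold lower number from compound 2 to compound 3 (0.88 log units; beyond the scatter). Compound 4 `O=C1CC(c2nc(-c3cccc(Cl)c3)no2)CN1c1cccc(Cl)c1` differs from compound 1 at a different place: 3-chlorophenyl in place of 4-chlorophenyl on an amide-type nitrogen in a ring. Among the measured compounds shown here, no measured step touches the ring on the amide-type nitrogen, so none bears directly on this change; the measured steps show only that this assay answers a single change of substituent with modest to large shifts. The expectation for compound 4 is therefore a modest step in this assay, with the direction uncertain and a higher number somewhat more likely, as a 2.3-fold higher number from compound 1 to compound 4 (0.36 log units; beyond the scatter). Compound 4 is estimated at 320 nM, expected to lie between 70 nM and 1500 nM.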

Compound 4, half-maximal effective concentration: > 10000 nM
Compound 4 was reported as a limit; the forecaster's own chance of this, stated with the estimate: 5%; at least 31-fold (1.49 log units) between middle value and limit.
By their numbers in this assay, from the lowest: compound 1; then compound 3; then compound 2. At a limit, above all of these: compound 4.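

Among the compounds shown here, with 3-chlorophenyl in place of 4-chlorophenyl on the amide-type nitrogen, the atoms and the counted features of the group stay the same, yet the result in this assay is an at least 71-fold higher number from compound 1 to compound 4 (1.85 log units; beyond the scatter) and it is the first measured change at this position. Going by these compounds, compound 4 is reported only as a limit, so the true size of this step stays unknown: the limit of > 10000 nM in this assay, at which 1 of the 4 values shown sits. Even the largest step on the other aromatic ring, a 34-fold higher number from compound 1 to compound 2 (1.54 log units; beyond the scatter), is smaller, so the aryl group on the amide-type nitrogen proves at least as demanding as that ring in this small set. The compounds shown leave open how a plain phenyl, a pyridine, or a methyl or methoxy group in place of the chlorine would read at this position. They also leave open whether 3-chlorophenyl would give the same result with fluoro or methoxy on the other aromatic ring.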